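The source may hold more compounds than are shown below. What is called first, only, known or untested is meant among the compounds shown, and "the series" means these compounds.

Working notes on the series. Compound 1 `O=C(Nc1ccc2ccc(O)nc2c1)c1ccc(-c2ccccc2)cc1` gives 8.5 in a functional assay for antagonist activity at transient receptor potential cation channel subfamily V member 1 (Homo sapiens), read by FLIPR and calcium flux; a lower number here means a less potent compound, a higher number a more potent compound, by a factor of ten per unit of this negative logarithm. Compound 2 `CC(=O)c1cccc(-c2ccc(C(=O)Nc3ccc4c(c3)N(C)CCC4)cc2)c1` gives 7 in this assay, and compound 3 `CN1CCCc2ccc(NC(=O)c3ccc(-c4cccs4)cc3)cc21` gives 7.6 in this assay. Compound 3 thus stands second highest of the three numbers: its nearest neighbour is compound 2, which lies lower by a gap beyond the scatter, and the furthest is compound 1, which lies higher by a gap beyond the scatter. Among the compounds with values here, the one measured step is a number 0.60 log units higher from compound 2 to compound 3 (beyond the scatter).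

Compound 4 `CN1CCCc2ccc(NC(=O)c3ccc(-n4cccn4)cc3)cc21` differs from compound 3 in a single place: 1H-pyrazol-1-yl in place of thiophen-2-yl on an aromatic carbon. Within the data shown here, the only measured step that bears on this position is a number 0.60 log units higher from compound 2 to compound 3 (beyond the scatter), which exchanged a six-membered for a five-membered aromatic ring on the same carbon. Among the measured compounds shown here, no measured step compares two five-membered aromatic rings with each other, so the swap in hand has no direct precedent. With that gap in the evidence, the expectation for compound 4 is a change of little size, at most within the scatter, leaning slightly lower, that is a number 0.30 log units lower from compound 3 to compound 4 (within the scatter) in this assay. Compound 4 is therefore estimated at 7.3 in this assay, with a range from 6.7 to 7.9.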

Compound 4, negative logarithm of the antagonist equilibrium constant: 6.9
Estimate against measurement, compound 4: 0.40 log units above, within the range that was stated.
By their numbers in this assay, from the lowest: compounds 4 and 2 (each within the scatter of the next); then compound 3; then compound 1.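

Five-membered aromatic rings on this aromatic carbon do not behave as one class, since the exchange of thiophen-2-yl for 1H-pyrazol-1-yl gives a number 0.70 log units lower from compound 3 to compound 4 (beyond the scatter) in this assay with the ring size unchanged and only the hetero atoms different. The gain from 3-acetylphenyl to thiophen-2-yl therefore cannot be credited to the smaller ring alone, as the other five-membered ring gives a number 0.10 log units lower from compound 2 to compound 4 (within the scatter) in this assay and so stands level with the six-membered, acetyl-bearing group. Within the data shown here, at this position the identity of the ring counts for more than its size, though this rests on only three groups, with compound 3 alone standing apart from the other two, and nothing available explains the difference between thiophen-2-yl and 1H-pyrazol-1-yl.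

Still open, as far as these compounds go, is how a non-aromatic group, such as a morpholine ring or a carboxylic acid, would fare on this carbon, para to a large group, on the core shared by compounds 2, 3 and 4. Compound 1 differs from these compounds in more than one place, so the compounds shown do not tell whether a plain phenyl ring at this position would match any of the three groups compared here.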